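The source may report more compounds than this note shows. Statements on the series, on what has been measured and on what is new or still open speak of the compounds shown alone.

Measured compounds:
- compound 1 `CC(C)(C)OC(=O)N1CCN(C(=S)SCc2cn(-c3ccccc3F)nn2)CC1`: 89600 nM
- compound 2 `O=C(OCc1ccccc1)N1CCN(C(=S)SCc2cn(Cc3ccccc3F)nn2)CC1`: 7950 nM
- compound 3 `Fc1ccccc1Cn1cc(CSC(=S)N2CCNCC2)nn1`: 33200 nM

In a functional assay on MCF7 cells (Homo sapiens) for inhibition, read by MTT assay, with a stated time of 72 h (a lower number here means a stronger inhibitor, a higher number a weaker inhibitor), compound 1 gives the highest number of the three; compound 3 sits nearest to it and compound 2 furthest, both with lower numbers. For the measured compounds named here, the only single-point step measured is a 4.2-fold higher number from compound 2 to compound 3 (0.62 log units; beyond the scatter), which concerns the piperazine nitrogen and does not touch the aromatic nitrogen of the core.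

Compound 4 `CC(C)(C)OC(=O)N1CCN(C(=S)SCc2cn(Cc3ccc(Cl)c(Cl)c3)nn2)CC1` differs from compound 1 by 3,4-dichlorobenzyl in place of 2-fluorophenyl on an aromatic nitrogen. Going by the values given here, no measured step bears on this change; compounds 1 and 2 differ at this position but also elsewhere, so their values only show that compound 2 sits lower than compound 1. The expectation for compound 4 is therefore a modest step, a 3.0-fold lower number from compound 1 to compound 4 (0.48 log units; beyond the scatter), toward a lower number, with wide uncertainty. Compound 4 is estimated at 30000 nM, expected between 8000 nM and 100000 nM.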

Compound 4, half-maximal inhibitory concentration: 19100 nM
The estimate for compound 4 lay 1.6-fold (0.20 log units) above the measured number; low and high end bracket the measured number.
By their numbers in this assay, from the lowest: compound 2; then compounds 4 and 3 (each within the scatter of the next); then compound 1.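

On the aromatic nitrogen, with the rest of the molecule held fixed, this assay gives a 4.7-fold lower number from compound 1 to compound 4 (0.67 log units; beyond the scatter) for 3,4-dichlorobenzyl in place of 2-fluorophenyl. For the compounds shown here, this position therefore moves the number on its own, which the earlier compounds could not show because compounds 1 and 2 also differ elsewhere. Nothing at hand explains the step.

Going by these compounds, this single change alters the ring substituents and adds a carbon, so their separate contributions remain open. Also open, on these data alone, is how an unsubstituted benzyl or a benzyl bearing a carboxylic acid would read at this position.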